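Replacing a Chain Alkene with a Ketone: One Step, Two Cores

A few compounds are considered here, and "the series" means these few. Any claim that something is new, unique, unknown or untested is made for them only; others in the source may bear on it.

Compound 1 `COc1cc(/C=C/C(=O)/C=C(O)/C=C/c2ccc(O[C@H]3C=C(C)[C@@H](O)C[C@@H]3[C@@H](C)CCC=C(C)C)c(OC)c2)ccc1O` and compound 2 `COc1cc(/C=C/C(=O)/C=C(O)/C=C/c2ccc(O[C@]3(C)C=C[C@@H]([C@@H](C)CCC=C(C)C)C[C@@H]3O)c(OC)c2)ccc1O` are built from the same atoms joined differently; the difference between the two cores is not broken down here. In a functional assay on HepG2 cells (Homo sapiens) for cytotoxicity, read by crystal violet staining, with a stated time of 72 h (on this read-out higher numbers stand for weaker inhibition and lower numbers for stronger inhibition), compound 1 gives 25000 nM, and compound 2 gives 35900 nM. Compound 3 `COc1cc(/C=C/C(=O)/C=C(O)/C=C/c2ccc(O[C@]3(C)C=C[C@@H]([C@@H](C)CC(=O)C=C(C)C)C[C@@H]3O)c(OC)c2)ccc1O` carries (2-methylprop-1-en-1-yl)carbonyl in place of 3-methylbut-2-en-1-yl on a saturated chain carbon, two bonds along the chain from a saturated ring carbon, and in this assay compound 3 gives 15700 nM, a step of a 2.3-fold lower number from compound 2 to compound 3 (0.36 log units; beyond the scatter). Compound 4 `COc1cc(/C=C/C(=O)/C=C(O)/C=C/c2ccc(O[C@H]3C=C(C)[C@@H](O)C[C@@H]3[C@@H](C)CC(=O)C=C(C)C)c(OC)c2)ccc1O` carries the same change on the core of compound 1: (2-methylprop-1-en-1-yl)carbonyl in place of 3-methylbut-2-en-1-yl on a saturated chain carbon, two bonds along the chain from a saturated ring carbon. The place is described in identical words in both cases, so this is the same change. Among the compounds with values here, compound 4 is expected to show a step of a 2.3-fold lower number from compound 1 to compound 4 (0.36 log units; beyond the scatter), because a 2.3-fold lower number from compound 2 to compound 3 (0.36 log units; beyond the scatter) stood beyond the scatter as the single measured instance of this change. Compound 4 is therefore estimated at 11000 nM, with a likely range from 5000 nM to 25000 nM.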

Compound 4, half-maximal inhibitory concentration: 15400 nM
Estimate against measurement, compound 4: 1.4-fold (0.15 log units) below; low and high end bracket the measured number.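

Putting (2-methylprop-1-en-1-yl)carbonyl in place of 3-methylbut-2-en-1-yl on the core of compound 1 gives, in this assay, a 1.6-fold lower number from compound 1 to compound 4 (0.21 log units; within the scatter), so this step alone is no clear change. Set beside the earlier step, it shows no measurable difference between the two cores: the same change on two cores in this assay, a 2.3-fold lower number (0.36 log units; beyond the scatter) from compound 2 to compound 3 and a 1.6-fold lower number (0.21 log units; within the scatter) from compound 1 to compound 4, 1.4-fold (0.15 log units) apart, within the scatter of two such steps. This means the two steps agree, but it does not show that the change truly lowers the number on the core of compound 1, or that it would carry to any further core.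

Going by these compounds, what remains open is how other groups at this place on the chain would behave, such as an amine or a carboxylic acid. A longer chain ending in the same carbonyl group is equally untested in the compounds shown.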